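Trimming the Sulfur Side Chain of Compound 3

This account rests on a few compounds, and the source may have more. Where it says the series, first, only, none or still open, it means among the compounds named here.

Compound 3 `CCCNC(=O)CSCC1C2CCC(O2)C1C/C=C\CCCC(=O)O` stands second highest of the three numbers in a functional assay on a cell-free system (plasma) with thromboxane A2 receptor (Homo sapiens) as the target (a higher number here means a weaker inhibitor, a lower number a stronger inhibitor), giving 72000 nM. Compound 1 `O=C(O)CCC/C=C\CC1C2CCC(O2)C1CSCCOc1ccccc1` gives 20000 nM, and compound 2 `O=C(O)CCC/C=C\CC1C2CCC(O2)C1CSC/C=C/c1ccccc1` gives 86000 nM; the step of a 3.6-fold higher number from compound 1 to compound 3 (0.56 log units; beyond the scatter) is modest, while a 1.2-fold lower number from compound 2 to compound 3 (0.08 log units; within the scatter) lies within the scatter. Compound 4 `CSCC1C2CCC(O2)C1C/C=C\CCCC(=O)O` differs from compound 3 by hydrogen in place of propylcarbamoyl on a saturated chain carbon bound to a sulfur. For the measured compounds named here, no measured step removes a group at this position outright; the two steps that touch it, a 4.3-fold higher number from compound 1 to compound 2 (0.63 log units; beyond the scatter) and a 3.6-fold higher number from compound 1 to compound 3 (0.56 log units; beyond the scatter), only exchange one substituent for another and are both modest. For compound 4 the step of a 2.1-fold higher number from compound 3 to compound 4 (0.32 log units; beyond the scatter) is expected to be upward, toward weaker inhibition. Compound 4 is estimated at 150000 nM, with a range from 40000 nM to 600000 nM.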

Compound 4, half-maximal inhibitory concentration: 38000 nM
Beside the measured number, compound 4's estimate is 3.9-fold (0.60 log units) above it; measured number outside the range, below it.
By their numbers in this assay, from the lowest: compounds 1, 4, 3 and 2 (each within the scatter of the next, the first and the last beyond it).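

Taking the side chain back to hydrogen shows that this position needs no substituent to stay in the same range in this assay, since a 1.9-fold lower number from compound 3 to compound 4 (0.28 log units; within the scatter) and a 1.9-fold higher number from compound 1 to compound 4 (0.28 log units; within the scatter) are both small enough to read as no change. The phenoxymethyl and propylcarbamoyl groups therefore add nothing that can be separated from hydrogen here. Only 2-phenylethenyl stands apart, with a 2.3-fold lower number from compound 2 to compound 4 (0.35 log units; beyond the scatter) as a modest step.

On these data alone, whether an amine, a carboxylic acid or a longer chain at this place would move the number beyond this range stays open. Nothing in the data explains these differences.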